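The source may hold more compounds than are shown below. What is called first, only, known or untested is meant among the compounds shown, and "the series" means these compounds.

Measured in an ADME assay on J774.A1 cells (Mus musculus) for cytotoxicity, read by MTT assay, with a stated time of 48 h; on this read-out higher numbers stand for lower toxicity in this test and lower numbers for higher toxicity in this test:
- Compound 1 `COc1ccc(/C=C(\C)C(=O)/C=C/c2ccccc2)cc1`: 54000 nM
- Compound 2 `COc1ccc(/C=C/C(=O)/C(C)=C/c2ccc(OC)cc2)cc1`: 34100 nM
- Compound 3 `COc1ccc(/C=C(\C)C(=O)/C=C/c2ccc([N+](=O)[O-])cc2)cc1`: 30000 nM

Compound 2, at 34100 nM, cannot be separated from the other two compounds. Its closest neighbour is compound 3, with a 1.1-fold lower number from compound 2 to compound 3 (0.06 log units; within the scatter), and its furthest is compound 1, with a 1.6-fold lower number from compound 1 to compound 2 (0.20 log units; within the scatter).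

Compound 4 `COc1ccc(/C=C/C(=O)/C(C)=C/c2ccc([N+](=O)[O-])cc2)cc1` has not yet been measured. It comes from compound 2 by putting nitro in place of methoxy on an aromatic carbon, para to a large group: nitro in place of methoxy on an aromatic carbon.

The closest guide is the same kind of exchange, a 1.1-fold lower number from compound 2 to compound 3 (0.06 log units; within the scatter). Adding nitro in place of hydrogen gave a 1.8-fold lower number from compound 1 to compound 3 (0.26 log units; within the scatter), and adding methoxy in place of hydrogen gave a 1.6-fold lower number from compound 1 to compound 2 (0.20 log units; within the scatter). None of these steps stands out from the scatter, but compound 3 and compound 4 are different compounds, so they offer only a rough guide.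

The expected outcome is a 1.1-fold lower number from compound 2 to compound 4 (0.06 log units; within the scatter), with no step beyond the scatter. For compound 4 the estimated value is 30000 nM, with an expected range from 14000 nM to 60000 nM.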

Compound 4, half-maximal cytotoxic concentration: 36600 nM
The estimate for compound 4 lay 1.2-fold (0.09 log units) below the measured number; measured number inside the range.
By their numbers in this assay, from the lowest: compounds 3, 2, 4 and 1 (each within the scatter of the next).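

In this assay, exchanging methoxy for nitro on this aromatic carbon, para to a large group, gives a 1.1-fold higher number from compound 2 to compound 4 (0.03 log units; within the scatter) and so produces no change that can be told from ordinary repeat variation. Compound 2 carries two methoxy groups, and exchanging the other one for nitro gives a 1.1-fold lower number from compound 2 to compound 3 (0.06 log units; within the scatter) as well, so this exchange has now been seen at both groups without a step beyond the scatter. Nothing measured here explains why these steps are so small.

As far as these compounds go, it remains open whether a different group at this place, such as an amine or a carboxylic acid, would produce a step beyond the scatter. From the compounds shown here alone, it is also open whether putting nitro in place of both methoxy groups at once would do so.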